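The source may hold more compounds than are shown below. What is called first, only, known or untested is meant among the compounds shown, and "the series" means these compounds.

Measured compounds:
- compound 1, `COc1ccc(S(=O)(=O)Oc2ccccc2NC(=O)c2ccc(F)cc2)cc1`: 550 nM
- compound 2, `COc1ccc(S(=O)(=O)Oc2ccccc2NC(=O)c2ccc(N(C)C)cc2)cc1`: > 10000 nM

In a functional assay on NCI-H460 cells (Homo sapiens) for antiproliferative activity (on this read-out lower numbers stand for stronger inhibition and higher numbers for weaker inhibition), compound 1 gives 550 nM. For compound 2 the read-out is a limit of the assay, > 10000 nM. Compound 2 therefore stands at the limit of > 10000 nM in this assay, at which 1 of the 2 values shown sits, and has no number of its own. For the measured compounds named here, the one measured step, an at least 18-fold higher number from compound 1 to compound 2 (1.25 log units; beyond the scatter), shows that the group on the carbonyl carbon matters and that dimethylamino there goes with the weaker result. Compound 3, `COc1ccc(S(=O)(=O)Oc2ccccc2NC(=O)c2ccc3ncccc3c2)cc1`, carries quinolin-6-yl in place of 4-(dimethylamino)phenyl on a carbonyl carbon. The measured step bears on this change only in part: neither fluoro nor dimethylamino is quinolin-6-yl, and no group with two rings has yet been measured in this assay. Since the step from compound 1 to compound 2 was large, a sizeable move is plausible; with compound 2 at the limit, the number can only come down or stay at the limit. Compound 3 is expected to give 2500 nM (500 nM to 10000 nM), an estimated step of an at least 4.0-fold lower number from compound 2 to compound 3 (0.60 log units; beyond the scatter).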

Compound 3, half-maximal inhibitory concentration: > 10000 nM
Compound 3 gave a limit, no number (the forecaster's own chance of this, stated with the estimate: 30%); middle value at least 4.0-fold (0.60 log units) away from the limit.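

In this assay, quinolin-6-yl on the carbonyl carbon gives an at least 18-fold higher number from compound 1 to compound 3 (1.25 log units; beyond the scatter), so a group with two rings there also goes with the weaker result, as dimethylamino did in compound 2. Compound 2 and compound 3 both stand at a limit, and the steps between them cannot be read, so 4-(dimethylamino)phenyl and quinolin-6-yl cannot be put in order. Of the three groups on this carbonyl carbon, only 4-fluorophenyl gives a number, and the other two stand at the limit: the limit of > 10000 nM in this assay, at which 2 of the 3 values shown sit.

Open, on these data alone, is whether 4-chlorophenyl, 4-methoxyphenyl or plain phenyl on the carbonyl carbon would give a number close to that of compound 1. Also open, as far as these compounds go, is whether naphthalen-2-yl, which has two rings of carbon only, would behave like quinolin-6-yl, which would separate the second ring from the ring nitrogen.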